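The source may report more compounds than this note shows. Statements on the series, on what has been measured and on what is new or still open speak of the compounds shown alone.

Measured so far in an assay on membranes from brain for displacement of a labelled ligand from Neuronal acetylcholine receptor; alpha4/beta2 (Rattus norvegicus), with a stated time of 3 h; on this read-out higher numbers stand for weaker inhibition and lower numbers for stronger inhibition: compound 1 `C(=C1\CCCN=C1c1cccnc1)\c1ccc(-n2ccnn2)cc1` gives 520 nM; compound 2 `CSc1ccc(/C=C2\CCCN=C2c2cccnc2)cc1` gives 900 nM; compound 3 `CC(=O)Oc1ccccc1/C=C1\CCCN=C1c1cccnc1` gives 700 nM.

Compound 3 stands second highest of these three numbers; its nearest neighbour is compound 2, and both that gap and the gap to compound 1 lie within the scatter. Compound 4 `C(=C1\CCCN=C1c1cccnc1)\c1ccccc1` differs from compound 3 by hydrogen in place of acetoxy on an aromatic carbon. Among the compounds with values here, the only measured step, a 1.7-fold higher number from compound 1 to compound 2 (0.24 log units; within the scatter), concerns a different group at a different place and lay within the scatter, so it gives no direct guide to hydrogen in place of acetoxy. Among compounds 1, 2 and 3, changes on the six-membered aromatic ring of carbon only have moved this assay little, so no step beyond the scatter is expected. Compound 4 is therefore estimated at 600 nM, between 250 nM and 1500 nM. That expectation amounts to a 1.2-fold lower number from compound 3 to compound 4 (0.07 log units; within the scatter).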

Compound 4, inhibition constant: 850 nM
For compound 4 the middle estimate is 1.4-fold (0.15 log units) below the measured one; the range from low to high includes it.
By their numbers in this assay, from the lowest: compounds 1, 3, 4 and 2 (each within the scatter of the next).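

Replacing each group with hydrogen on the aromatic carbon leaves this assay within the scatter: acetoxy gives way to hydrogen (a 1.2-fold higher number from compound 3 to compound 4 (0.08 log units; within the scatter)), as do methylsulfanyl (a 1.1-fold lower number from compound 2 to compound 4 (0.02 log units; within the scatter)) and 1H-1,2,3-triazol-1-yl (a 1.6-fold higher number from compound 1 to compound 4 (0.21 log units; within the scatter)). The earlier compounds shown here all carried a group there, so only now can these three be read against hydrogen, and none stands apart from it. No available evidence accounts for this. As far as these compounds go, whether an amine, a carboxylic acid or a longer chain on this aromatic carbon would also stay within the scatter of hydrogen remains open.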